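The source may report more compounds than this note shows. Statements on the series, on what has been measured and on what is new or still open speak of the compounds shown alone.

Among the compounds with values here, compound 1 `COc1nc(-c2ccccc2)cc(-c2ccc(F)cc2)c1C#N` gives 25 nM in an assay on isolated protein for inhibition of sulfide:quinone oxidoreductase, mitochondrial (Homo sapiens) (on this read-out higher numbers stand for weaker inhibition and lower numbers for stronger inhibition), the lowest of the three numbers so far. Compound 2 `COc1cccc(-c2cc(-c3ccc(F)cc3)c(C#N)c(OC)n2)c1` gives 108 nM in this assay and compound 3 `COc1ccccc1-c1cc(-c2ccc(F)cc2)c(C#N)c(OC)n1` gives 75 nM. The known steps are a 4.3-fold higher number from compound 1 to compound 2 (0.64 log units; beyond the scatter) and a 3.0-fold higher number from compound 1 to compound 3 (0.48 log units; beyond the scatter), with a 1.4-fold lower number from compound 2 to compound 3 (0.16 log units; within the scatter) between the two methoxy compounds. Compound 4 `COc1nc(-c2ccccc2)cc(-c2ccc(Cl)cc2)c1C#N` differs from compound 1 by chloro in place of fluoro on an aromatic carbon. Within the data shown here, none of the measured steps bears on this change: all three concern a methoxy group, not the halogen. With nothing to lean on, the step is expected to stay within the scatter, a 1.1-fold lower number from compound 1 to compound 4 (0.06 log units; within the scatter). Compound 4 is therefore estimated at 22 nM in this assay, with a range of 9 nM to 55 nM.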

Compound 4, half-maximal inhibitory concentration: 252 nM
Beside the measured number, compound 4's estimate is 11-fold (1.06 log units) below it; measured number outside the range, above it.
By their numbers in this assay, from the lowest: compound 1; then compounds 3 and 2 (each within the scatter of the next); then compound 4.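

In this assay, chloro in place of fluoro, para to a large group, gives a 10-fold higher number from compound 1 to compound 4 (1.00 log units; beyond the scatter). The earlier steps shown here concerned only methoxy groups; this one shows that the series responds to a single-atom exchange at this halogen position, with the counts of hydrogen-bond donors and acceptors and the net charge unchanged. Nothing available accounts for the size of this step. As far as these compounds go, what an amine or a methyl group at this position would give remains open. Also open, from the compounds shown here alone, is whether the same step would hold in compound 2 or compound 3, which carry a methoxy group.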